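The compounds below may be only part of what the source reports. "The series", "measured", "known", "first", "only" and "open" are said of these compounds alone.

The series shown here is assayed in a functional assay on A549 cells (Homo sapiens) for cytotoxicity, read by sulforhodamine B assay; on this read-out higher numbers stand for weaker inhibition and lower numbers for stronger inhibition. Compound 1 `Cc1ccc2c(=O)n(C)c3c(c2c1)CCOc1ccccc1-3` gives 61300 nM there, and compound 2 `Cc1ccc2c3c(n(C)c(=O)c2c1)-c1ccccc1OCC3` gives 30300 nM. Compound 3 `COCOc1ccccc1-c1cc2ccccc2c(=O)[nH]1`, which carries a methoxymethyl ether on a phenyl ring attached to a bicyclic lactam core, gives 23600 nM in this assay. Among the three numbers this is the lowest, but the gap to compound 2 lies within the scatter of repeated measurements, so compound 3 and compound 2 cannot be told apart; only compound 1 sits clearly apart from compound 3, beyond the scatter.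

The account then moves to compound 4 `COCOc1ccccc1-c1cc2cc(C)ccc2c(=O)[nH]1`, not yet measured in this assay. Compound 4 differs from compound 3 by methyl in place of hydrogen on an aromatic carbon, that is, a methyl in place of hydrogen on an aromatic carbon of the fused ring of the lactam core, leaving the ether and the attached phenyl untouched. Going by the values given here, no measured pair in this set shows what such a methyl does on this core, and the other two compounds sit on a different ring system, so they cannot supply a step. The expected change from compound 3 to compound 4 is therefore a 1.2-fold lower number from compound 3 to compound 4 (0.07 log units; within the scatter), a step that is estimated to lie within the scatter in either direction rather than beyond it. On that basis compound 4 is expected to give about 20000 nM in this assay, with a plausible range from 8000 nM to 50000 nM.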

Compound 4, half-maximal inhibitory concentration: > 100000 nM
Compound 4 ended at the assay's limit; the forecaster's own chance of this, stated with the estimate: 5%; middle value at least 5.0-fold (0.69 log units) from the limit.
By their numbers in this assay, from the lowest: compounds 3 and 2 (each within the scatter of the next); then compound 1. At a limit, above all of these: compound 4.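

Going by these compounds alone, at this position, on an aromatic carbon of a six-membered aromatic ring of carbon only, part of a fused system of two rings, methyl in place of hydrogen provides the first single-place step: in this assay it gives an at least 4.2-fold higher number from compound 3 to compound 4 (0.62 log units; beyond the scatter). Compound 4 gives > 100000 nM in this assay, and this value is a limit of the assay, not a number. The change of a single heavy atom is thus enough to weaken inhibition beyond the scatter on this core, but only a minimum size can be read for the step, because the value of compound 4 sits at the limit: the limit of > 100000 nM in this assay, at which 1 of the 4 values shown sits.

The compounds shown leave open whether this weakening is particular to methyl or would also follow from another group at this position, such as a chlorine atom, a methoxy group, an amine or a carboxylic acid. They also leave open how the same methyl would behave with a hydroxyl group in place of the methoxymethyl ether on the attached phenyl ring.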